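Moving the Chlorine: One Change Tested on Two Cores

This account rests on a few compounds, and the source may have more. Where it says the series, first, only, none or still open, it means among the compounds named here.

Measured compounds, with their values in a functional assay on SGC-7901 cells (Homo sapiens) for antiproliferative activity, read by MTT assay, with a stated time of 24 h; a higher number here means a weaker inhibitor, a lower number a stronger inhibitor:
compound 1, `O=c1[nH]cc(S(=O)(=O)Nc2ccccc2-c2cn(-c3ccccc3Cl)nn2)c(=O)[nH]1`, 6520 nM
compound 2, `O=c1[nH]cc(S(=O)(=O)Nc2ccccc2-c2cn(-c3cccc(Cl)c3)nn2)c(=O)[nH]1`, 2270 nM
compound 3, `O=c1[nH]cc(S(=O)(=O)Nc2cccc(-c3cn(-c4ccccc4Cl)nn3)c2)c(=O)[nH]1`, 3010 nM

The pair compound 1 and compound 2 differ by one change, (3-chlorophenyl in place of 2-chlorophenyl on an aromatic nitrogen), and it produced a 2.9-fold lower number from compound 1 to compound 2 (0.46 log units; beyond the scatter). Compound 3 carries a different core from compound 1; that difference is not broken down here. Compound 4, `O=c1[nH]cc(S(=O)(=O)Nc2cccc(-c3cn(-c4cccc(Cl)c4)nn3)c2)c(=O)[nH]1`, is not yet measured and stands to compound 3 as compound 2 stands to compound 1: 3-chlorophenyl in place of 2-chlorophenyl on an aromatic nitrogen, at the same place and so the same change. Going by the values given here, the expected step from compound 3 to compound 4 is a 2.5-fold lower number from compound 3 to compound 4 (0.40 log units; beyond the scatter) in this assay; this rests on the single earlier instance, a 2.9-fold lower number from compound 1 to compound 2 (0.46 log units; beyond the scatter), tempered a little since one pair alone cannot show how far the gain carries over to another core. Compound 4 is therefore estimated at 1200 nM, with a likely range of 500 nM to 3000 nM.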

Compound 4, half-maximal inhibitory concentration: 3950 nM
The estimate for compound 4 lay 3.3-fold (0.52 log units) below the measured number; measured number above the stated range.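

On the core of compound 3, putting 3-chlorophenyl in place of 2-chlorophenyl on the aromatic nitrogen gave a 1.3-fold higher number from compound 3 to compound 4 (0.12 log units; within the scatter) in this assay, so the gain seen on the core of compound 1 did not reappear. The same change thus behaved differently on the two cores: the same change on two cores in this assay, a 2.9-fold lower number (0.46 log units; beyond the scatter) from compound 1 to compound 2 and a 1.3-fold higher number (0.12 log units; within the scatter) from compound 3 to compound 4, 3.8-fold (0.58 log units) apart, beyond the scatter of two such steps. This does not show which feature of the cores sets the two results apart, and two pairs say nothing about how the change would behave on a third core.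

Going by these compounds, whether a methoxy group, a fluorine, an amine or a carboxylic acid in place of the chlorine would also depend on the core remains open. So does the result for a plain phenyl on that nitrogen.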